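The source may hold more compounds than are shown below. What is called first, only, known or untested is meant among the compounds shown, and "the series" means these compounds.

Of the compounds shown here, three sharing one core have been measured in a functional assay for inhibition of sodium/hydrogen exchanger (Oryctolagus cuniculus); on this read-out lower numbers stand for stronger inhibition and higher numbers for weaker inhibition. Compound 1 `CSc1cc(C)c(C(=O)N=C(N)N)cc1S(C)(=O)=O` gives 6 nM. Compound 2 `Cc1cc(Sc2ccccc2)c(S(C)(=O)=O)cc1C(=O)N=C(N)N`, with phenyl in place of methyl on a sulfur, gives 14 nM, a step of a 2.3-fold higher number from compound 1 to compound 2 (0.37 log units; beyond the scatter). Compound 3 `Cc1cc(OCc2ccccc2)c(S(C)(=O)=O)cc1C(=O)N=C(N)N`, with benzyloxy in place of methylsulfanyl on an aromatic carbon, gives 28 nM; the step is a 4.7-fold higher number from compound 1 to compound 3 (0.67 log units; beyond the scatter). On these numbers compound 3 stands highest of the three, but its gap to compound 2, a 2.0-fold higher number from compound 2 to compound 3 (0.30 log units; within the scatter), lies within the scatter, so the two cannot be ranked against each other.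

Compound 4 `Cc1cc(Nc2cccc(Cl)c2)c(S(C)(=O)=O)cc1C(=O)N=C(N)N` differs from compound 3 in one place: (3-chlorophenyl)amino in place of benzyloxy on an aromatic carbon. The measured steps bear on this only loosely. Both compound 2 and compound 3 carry an aromatic ring attached through a single linking atom at that carbon, and they sit close together in this assay. Compound 4 again carries an aromatic ring on one linking atom, now with a hydrogen-bond donor, so a number near those of compounds 2 and 3 is expected, with no step beyond the scatter clearly indicated. The estimate for compound 4 is 20 nM, within 7 nM to 60 nM, which corresponds to an expected step of a 1.4-fold lower number from compound 3 to compound 4 (0.15 log units; within the scatter).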

Compound 4, half-maximal inhibitory concentration: 33 nM
Estimate against measurement, compound 4: 1.7-fold (0.22 log units) below; the range from low to high includes it.
By their numbers in this assay, from the lowest: compound 1; then compounds 2, 3 and 4 (each within the scatter of the next, the first and the last beyond it).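

In this assay, replacing benzyloxy with (3-chlorophenyl)amino on the aromatic carbon ortho to the methylsulfonyl group brings in a hydrogen-bond donor and a chlorine, yet the result stays within the scatter (a 1.2-fold higher number from compound 3 to compound 4 (0.07 log units; within the scatter)), so this position accepts that swap without a readable change. The comparison with the phenylsulfanyl group does pass the scatter, though only modestly (a 2.4-fold higher number from compound 2 to compound 4 (0.37 log units; beyond the scatter)), and the small methylsulfanyl group of compound 1 still gives the lowest number (a 5.5-fold higher number from compound 1 to compound 4 (0.74 log units; beyond the scatter)), so all three larger aromatic groups now lie beyond the scatter from compound 1 and none goes against this. Nothing available here explains these numbers.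

As far as these compounds go, compound 4 changes the link to the ring and adds a chlorine in a single step, so the share of each remains unknown, and an unsubstituted phenylamino group would be needed to separate them. From the compounds shown here alone, how a small dimethylamino group or a piperidine would read at this carbon also remains open.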